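Series notes: aryl-substituent change on the shared core

The source may hold more compounds than are shown below. What is called first, only, known or untested is meant among the compounds shown, and "the series" means these compounds.

Measured compounds:
compound 1, `CC(C)(Oc1ccc(F)cc1)C1OCC(C/C=C\CCC(=O)O)C(c2cccnc2)O1`, 120 nM
compound 2, `COc1ccc(SC(C)(C)C2OCC(C/C=C\CCC(=O)O)C(c3cccnc3)O2)c([N+](=O)[O-])c1`, 158 nM

Both values come from a functional assay for inhibition, with Homo sapiens as the target; on this read-out higher numbers stand for weaker binding and lower numbers for tighter binding. Compound 1 gives 120 nM, the lower of the two numbers; compound 2 gives 158 nM, and the gap between these two lies within the scatter, so the two values are read as equivalent. Among the measured compounds shown here, compound 2 differs from compound 1 in more than one place, so no single-point step can be drawn between them, and the pair only shows that two quite different aryl groups on the shared core give the same level of result in this assay.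

The unmeasured compound 3, `CC(C)(Cc1ccc(F)cc1C#N)C1OCC(C/C=C\CCC(=O)O)C(c2cccnc2)O1`, departs from compound 1 by the change (a group of 10 heavy atoms (8 carbon, 1 nitrogen, 1 fluorine; one six-membered aromatic ring of carbon only) in place of a group of 8 heavy atoms (6 carbon, 1 oxygen, 1 fluorine; one six-membered aromatic ring of carbon only), on a saturated chain carbon bound to two saturated chain carbons and a saturated ring carbon). No step involving this change has been measured, so the expectation rests only on the tolerance of the core to aryl variation shown by compound 1 and compound 2.

The step from compound 1 to compound 3 in this assay is expected to be a 1.3-fold higher number from compound 1 to compound 3 (0.10 log units; within the scatter), that is, no clear movement beyond the scatter in either direction. Compound 3 is therefore estimated at 150 nM, with a range of 50 nM to 450 nM.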

Compound 3, dissociation constant: 2.19 nM
Compound 3: the middle estimate sits 68-fold (1.84 log units) above what was measured; the measured number lies below the stated range.
By their numbers in this assay, from the lowest: compound 3; then compounds 1 and 2 (each within the scatter of the next).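

In this assay, among the compounds shown here, the step at this position reads a 55-fold lower number from compound 1 to compound 3 (1.74 log units; beyond the scatter) and is large, so the saturated chain carbon bound to two saturated chain carbons and a saturated ring carbon is a place where the group carried can move the read-out strongly, something the earlier pair, with no single-place step between them, could not show. The change removes 4-fluorophenoxy and brings in a group of 10 heavy atoms with one six-membered aromatic ring of carbon only and a triple bond outside aromatic rings, while hydrogen-bond donor count, acceptor count and net charge stay the same, so those counts do not tell the two groups apart. Nothing at hand accounts for the size of the step.

The compounds shown leave open which part of the entering group carries the step, a question that a plain 4-fluorobenzyl group or a 4-fluorophenoxy group bearing a nitrile would address. Also open, as far as these compounds go, is whether a trifluoromethyl or a carboxamide in place of the nitrile would keep the number as low as that of compound 3 2.19 nM in this series.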